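Moving the Halogen on the Benzyloxy Pyridinone Arm

A few compounds are considered here, and "the series" means these few. Any claim that something is new, unique, unknown or untested is made for them only; others in the source may bear on it.

The two measured compounds share one core and differ only in the halogen on the benzyl group. Compound 1 `Cn1c(C2CC2)nc2ccc(-n3ccc(OCc4ccc(Cl)cc4)cc3=O)cc21` gives 21 nM in an assay on CHO cells for displacement of a labelled ligand from melanin-concentrating hormone receptor 1 (Rattus norvegicus), read by scintillation counting, with a stated time of 1 h; a lower number here means a stronger inhibitor, a higher number a weaker inhibitor. Compound 2 `Cn1c(C2CC2)nc2ccc(-n3ccc(OCc4ccc(F)cc4)cc3=O)cc21` gives 28 nM in this assay, which is the higher of the two numbers, although the step of a 1.3-fold higher number from compound 1 to compound 2 (0.12 log units; within the scatter) lies within the scatter, so the two compounds cannot be ordered.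

Compound 3 `Cn1c(C2CC2)nc2ccc(-n3ccc(OCc4cccc(Cl)c4)cc3=O)cc21` is not yet measured. It differs from compound 2 by 3-chlorophenyl in place of 4-fluorophenyl on a saturated chain carbon bound to an oxygen on an aromatic ring. This change does two things at once: it swaps fluorine for chlorine, and it moves the halogen to a different position on the ring. Among the compounds with values here, the only measured step that bears on it is the halogen swap a 1.3-fold higher number from compound 1 to compound 2 (0.12 log units; within the scatter), which was small. Within the data shown here, no measured pair speaks to the shift of position, so that part of the change is untested here.

Given the small size of the one relevant step, compound 3 is expected to stay close to compound 2, with a step of about a 1.1-fold higher number from compound 2 to compound 3 (0.06 log units; within the scatter). The estimate for compound 3 is 32 nM, within a range from 10 nM to 100 nM.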

Compound 3, half-maximal inhibitory concentration: 72 nM
For compound 3 the middle estimate is 2.3-fold (0.35 log units) below the measured one; the range from low to high includes it.
By their numbers in this assay, from the lowest: compounds 1 and 2 (each within the scatter of the next); then compound 3.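

Within the data shown here, with chlorine kept and only its place on the ring changed, 3-chlorophenyl in place of 4-chlorophenyl gives a 3.4-fold higher number from compound 1 to compound 3 (0.54 log units; beyond the scatter) in this assay, the first measured step that isolates the position of the halogen on this arm. The change from 4-fluorophenyl to 3-chlorophenyl, which alters both the halogen and its position, gives a 2.6-fold higher number from compound 2 to compound 3 (0.41 log units; beyond the scatter), so this arm, which showed only a 1.3-fold higher number from compound 1 to compound 2 (0.12 log units; within the scatter) when one halogen replaced the other in the same position, proves sensitive to a change that includes a shift of position. The data shown offer no measurement that accounts for the weaker binding of the 3-chlorophenyl compound.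

The compounds shown leave open whether fluorine would respond as chlorine does when moved in the same way, so it remains unknown whether the effect of the shift depends on the halogen. From the compounds shown here alone, it is also open whether a halogen is needed on this ring at all, and how a plain phenyl ring, or one bearing a methoxy or nitrile group, would compare with the three halogenated benzyl groups.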